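Series notes: side chain on the ring nitrogen of a nucleoside core

This account rests on a few compounds, and the source may have more. Where it says the series, first, only, none or still open, it means among the compounds named here.

Measured so far:
compound 1 `[N-]=[N+]=NCC(O)Cn1c(=O)n(C2OC(CO)[C@@H](O)[C@H]2O)c2nc(N)nc(O)c21` — 39 uM
compound 2 `Cn1c(=O)n(C2OC(CO)[C@@H](O)[C@H]2O)c2nc(N)nc(O)c21` — 10 uM
compound 3 `NC(=O)Cn1c(=O)n(C2OC(CO)[C@@H](O)[C@H]2O)c2nc(N)nc(O)c21` — 190 uM

All three were tested in a functional assay (B cells) with Mus musculus as the target; on this read-out higher numbers stand for an effect only at larger amounts of compound and lower numbers for an effect already at smaller amounts. Compound 3 gives the highest number of the three: a 4.9-fold higher number from compound 1 to compound 3 (0.69 log units; beyond the scatter) and a 19-fold higher number from compound 2 to compound 3 (1.28 log units; beyond the scatter) both show that carbamoyl at this position is the least favourable of the groups seen so far.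

Compound 4 `NCC(O)Cn1c(=O)n(C2OC(CO)[C@@H](O)[C@H]2O)c2nc(N)nc(O)c21` is not yet measured. Its change from compound 3 is 2-amino-1-hydroxyethyl in place of carbamoyl on a saturated chain carbon bound to an aromatic nitrogen. Among the measured compounds shown here, the closest precedent is compound 1, whose 2-azido-1-hydroxyethyl at the same position gives a modestly lower number than compound 3. For the measured compounds named here, only the terminal group differs between compound 1 and compound 4, and no step separates azide from amine here. For compound 4 the expected step is a 4.8-fold lower number from compound 3 to compound 4 (0.68 log units; beyond the scatter), a lower number than compound 3. Compound 4 is thus estimated at 40 uM, within 10 uM to 150 uM.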

Compound 4, concentration for half-maximal effect: 28 uM
Compound 4: middle estimate off by 1.4-fold (0.15 log units), on the high side; measured number inside the range.
By their numbers in this assay, from the lowest: compound 2; then compounds 4 and 1 (each within the scatter of the next); then compound 3.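

In this assay, the amino and azido end groups of the chain cannot be told apart (a 1.4-fold lower number from compound 1 to compound 4 (0.14 log units; within the scatter)), so this exchange at the chain end shows no effect beyond the scatter. The 2-amino-1-hydroxyethyl chain gives a lower number than carbamoyl (a 6.8-fold lower number from compound 3 to compound 4 (0.83 log units; beyond the scatter)) but a higher number than hydrogen (a 2.8-fold higher number from compound 2 to compound 4 (0.45 log units; beyond the scatter)), so the azido result is not specific to that end group. No available evidence bears on the cause of these steps.

Still open, as far as these compounds go, is how a chain without the hydroxyl would read, and whether a dimethylamino or carboxylic acid end group, or a longer chain, would approach compound 2.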